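The source may hold more compounds than are shown below. What is called first, only, known or untested is meant among the compounds shown, and "the series" means these compounds.

Three compounds share a nucleoside core and were tested in a functional assay on A549 cells (Homo sapiens), read by MTT assay, with a stated time of 72 h; a lower number here means a stronger inhibitor, a higher number a weaker inhibitor. Compound 1 `C#Cc1cn([C@@H]2O[C@H](CO)[C@@H](O)[C@H]2O)c2ncnc(OC)c12` gives 8160 nM. Compound 2 `COc1ncnc2c1c(-c1cccs1)cn2[C@@H]1O[C@H](CO)[C@@H](O)[C@H]1O` gives 4850 nM, and compound 3 `COc1ncnc2c1c(-c1ccco1)cn2[C@@H]1O[C@H](CO)[C@@H](O)[C@H]1O` gives 30 nM. Compound 2 stands second highest of these three numbers: its value and that of compound 1 lie within the scatter of each other, as the step of a 1.7-fold lower number from compound 1 to compound 2 (0.23 log units; within the scatter) shows, while compound 3 is far apart, the step of a 160-fold lower number from compound 2 to compound 3 (2.21 log units; beyond the scatter) being large and well beyond the scatter, as is a 270-fold lower number from compound 1 to compound 3 (2.43 log units; beyond the scatter).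

Compound 4 `CNc1ncnc2c1c(-c1cccs1)cn2[C@@H]1O[C@H](CO)[C@@H](O)[C@H]1O` is not yet measured. It differs from compound 2 in one place: methylamino in place of methoxy on an aromatic carbon. Among the measured compounds shown here, none of the measured steps touches this position; all three exchange the group on the five-membered ring of the core, and the group at the place now changed stays methoxy throughout. The data give no direct guide to the direction or size of this change, so the step from compound 2 to compound 4 is estimated as a 1.4-fold lower number from compound 2 to compound 4 (0.14 log units; within the scatter), an expected step only. With compound 2 as the nearest anchor, compound 4 is estimated to give about 3500 nM, with a wide range from 600 nM to 20000 nM, a step that is expected to stay within the scatter.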

Compound 4, half-maximal inhibitory concentration: > 20000 nM
Compound 4 was reported as a limit; the forecaster's own chance of this, stated with the estimate: 15%; at least 5.7-fold (0.75 log units) between middle value and limit.
By their numbers in this assay, from the lowest: compound 3; then compounds 2 and 1 (each within the scatter of the next). At a limit, above all of these: compound 4.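

In this assay, among the compounds shown here, the earlier steps changed only the other group on the shared core, with methoxy held fixed, so compound 4 gives the first reading at this place on the six-membered aromatic ring with 2 nitrogen. With thiophen-2-yl kept, methylamino in place of methoxy gives an at least 4.1-fold higher number from compound 2 to compound 4 (0.61 log units; beyond the scatter), which shows that activity here is sensitive to an exchange that leaves the heavy-atom count unchanged but swaps oxygen for nitrogen and adds a hydrogen-bond donor. Compound 4 is reported as a limit, not as a number: the limit of > 20000 nM in this assay, at which 1 of the 4 values shown sits.

The compounds shown cannot separate the effect of the added donor from that of the nitrogen itself, and a plain amine or a dimethylamino group at this place would help to tell these apart. On these data alone, it also remains open whether methylamino would have a similar effect with furan-2-yl in place of thiophen-2-yl, the pairing that would extend this comparison to compound 3.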